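Dithiocarbamate series: amine swap at the thiocarbonyl carbon

A few compounds are considered here, and "the series" means these few. Any claim that something is new, unique, unknown or untested is made for them only; others in the source may bear on it.

The set holds four compounds on two related cores. Compound 3 `CC(C)N(C(=S)SCc1coc2ccccc2c1=O)C(C)C` carries a diisopropylamino group on the thiocarbonyl carbon; compound 2 `O=c1c(CSC(=S)N2CCOCC2)coc2ccccc12` is its morpholine counterpart on the same core. Compound 1 `CC(C)N(C(=S)SCc1cc(=O)c2ccccc2o1)C(C)C` has the diisopropylamino group on the other core, and compound 4 `O=c1cc(CSC(=S)N2CCOCC2)oc2ccccc12` is the morpholine counterpart of compound 1, not yet measured. The difference between the two cores is not broken down here.

In a functional assay on SW480 cells (Homo sapiens) for antiproliferative activity, read by MTT assay, with a stated time of 72 h (a lower number here means a stronger inhibitor, a higher number a weaker inhibitor), compound 3 gives 6800 nM. In this assay compound 2 gives 5900 nM. The change between them is morpholin-4-yl in place of diisopropylamino on a thiocarbonyl carbon and the step is a 1.2-fold lower number from compound 3 to compound 2 (0.06 log units; within the scatter). For compound 1 this assay reports only a limit, > 40000 nM, so no number is known for it.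

The same change, (morpholin-4-yl in place of diisopropylamino on a thiocarbonyl carbon), links compound 1 to compound 4; the two place lines agree word for word, so it is the same change as the one already measured. Since that step stayed within scatter, compound 4 is expected to remain close to compound 1, with an expected step that the limit leaves unreadable from compound 1 to compound 4. That expectation rests on compound 1 sitting at the limit (the limit of > 40000 nM in this assay, at which 1 of the 3 values shown sits), which leaves only the chance that compound 4 drops slightly into the measurable range. Compound 4 is therefore estimated at 45000 nM, with a range of 15000 nM to 150000 nM.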

Compound 4, half-maximal inhibitory concentration: 24400 nM
Compound 4: middle estimate off by 1.8-fold (0.27 log units), on the high side; measured number inside the range.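

In this assay, the change from diisopropylamino to morpholin-4-yl on the thiocarbonyl carbon can now be set side by side on both cores, and on the second core the step reads an at least 1.6-fold lower number from compound 1 to compound 4 (0.21 log units; that floor lies within the scatter). That figure is only a floor, as the value for compound 1 is a limit and not a number: the limit of > 40000 nM in this assay, at which 1 of the 4 values shown sits. The pair of steps therefore shows neither that the change carries unaltered from one core to the other nor that its size depends on the core, and the comparison stays undecided: the same change on two cores in this assay, a 1.2-fold lower number (0.06 log units; within the scatter) from compound 3 to compound 2 and an at least 1.6-fold lower number (0.21 log units; that floor lies within the scatter) from compound 1 to compound 4; the limit leaves it open whether they differ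

The compounds shown leave open how large the step from compound 1 to compound 4 really is, and how the two cores compare when the amine on the thiocarbonyl carbon is held fixed. They also leave open whether another amine in the same place, such as piperidine, N-methylpiperazine or dimethylamine, would track the morpholin-4-yl result on both cores or would separate them.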